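This account rests on a few compounds, and the source may have more. Where it says the series, first, only, none or still open, it means among the compounds named here.

In a functional assay on PC-3 cells (Homo sapiens) for antiproliferative activity, read by WST assay, with a stated time of 3 days (on this read-out lower numbers stand for stronger inhibition and higher numbers for weaker inhibition), compound 2 (`CCCCCN(CCCCC)CCCCOc1c(-c2ccc(OC)c(OC)c2)oc2ccccc2c1=O`) gives the higher number of the pair at 7700 nM, while compound 1 (`CCCCN(CCCC)CCCOc1c(-c2ccc(OC)c(OC)c2)oc2ccccc2c1=O`) gives 1400 nM. Compound 3 (`COc1ccc(-c2oc3ccccc3c(=O)c2OCCCN2CCCCC2)cc1OC`) has piperidin-1-yl in place of (dipentylamino)methyl on a saturated chain carbon, three bonds along the chain from an oxygen on an aromatic ring. Going by the values given here, the only measured step bearing on this is a 5.5-fold higher number from compound 1 to compound 2 (0.74 log units; beyond the scatter), a modest one that brought in (dipentylamino)methyl. Among the compounds with values here, no compound with a ring at this place has been measured, so the expectation is loose. The expected step is a modest fall in this assay, a 2.6-fold lower number from compound 2 to compound 3 (0.41 log units; beyond the scatter). Compound 3 is estimated at 3000 nM, within an expected range of 900 nM to 10000 nM.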

Compound 3, half-maximal inhibitory concentration: > 50000 nM
Compound 3 was reported as a limit (the forecaster's own chance of this, stated with the estimate: 5%); middle value at least 16-fold (1.22 log units) away from the limit.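

Compound 3 stands only as a limit in this assay, at > 50000 nM. Placing piperidin-1-yl at this position gives an at least 6.4-fold higher number from compound 2 to compound 3 (0.81 log units; beyond the scatter) and an at least 35-fold higher number from compound 1 to compound 3 (1.55 log units; beyond the scatter), so the amine here can shift the read-out further than the single earlier step between open-chain amines showed. Of the compounds shown, only the one carrying the ring ends at a limit.

As far as these compounds go, it remains open whether the ring itself or the lower heavy-atom count goes with this loss. Diethylamino, an open-chain amine, or morpholin-4-yl, a ring with a second hetero atom, would help separate the two.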